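The source may report more compounds than this note shows. Statements on the series, on what has been measured and on what is new or still open speak of the compounds shown alone.

Compound 1 `CCOC(=O)c1cc(=O)c2cc(CSC(=S)N(C)c3ccccc3)ccc2o1` gives 18100 nM in a functional assay on HeLa cells (Homo sapiens) for antiproliferative activity, read by MTT assay, with a stated time of 72 h; a higher number here means a weaker inhibitor, a lower number a stronger inhibitor. Compound 2 `COc1ccc2oc(CSC(=S)N3CCOCC3)cc(=O)c2c1` reaches only the limit of this assay, > 25000 nM. Compound 3 `O=c1cc(CSC(=S)N2CCCCC2)oc2cc(Cl)ccc12` also sits at the limit of this assay, > 25000 nM.

Compound 3 thus stands among the values that are limits and not numbers: of the three values shown, two are such limits, and compound 3 holds one of them (the limit of > 25000 nM in this assay, at which 2 of the 3 values shown sit). Only compound 1 yields an actual number in this assay, and even that number lies far from the strong end of the scale.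

Compound 4 `O=c1cc(CSC(=S)N2CCCCC2)oc2ccccc12` differs from compound 3 by hydrogen in place of chloro on an aromatic carbon. Within the data shown here, no pair of measured compounds shows this change on its own, so the step is expected to be small and without clear direction, not beyond the scatter, an expected step of a number no higher from compound 3 to compound 4 (the limit leaves the size open). Compound 4 is therefore estimated at 25000 nM, within 8000 nM to 60000 nM, with a good chance that only the limit is reported again.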

Compound 4, half-maximal inhibitory concentration: > 25000 nM
Compound 4: no number, only a limit (the forecaster's own chance of this, stated with the estimate: 60%); the middle value sits exactly at the limit.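

Compound 3 and compound 4 both stand at a limit in this assay, so no step can be read from compound 3 to compound 4, and the swap of chloro for hydrogen stays without a size. What the compounds shown leave open is whether this change on an aromatic carbon moves the value at all: the limit of > 25000 nM in this assay, at which 3 of the 4 values shown sit.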